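The source may report more compounds than this note shows. Statements on the series, on what has been measured and on what is new or still open speak of the compounds shown alone.

Measured so far in an assay on HEK293 cells for antagonist activity at P2X purinoceptor 7 (Homo sapiens), read by fluorescence, with a stated time of 2 h; on this read-out lower numbers stand for stronger inhibition and higher numbers for weaker inhibition:
compound 1 `CN(C)c1ccc(C(=O)N2CCC(n3cncc3-c3ccc(OS(=O)(=O)c4cccc5cnccc45)cc3)CC2)cc1` — 0.11 nM
compound 2 `CS(=O)(=O)c1ccc(C(=O)N2CCC(n3cncc3-c3ccc(OS(=O)(=O)c4cccc(C#N)c4)cc3)CC2)cc1` — 143 nM
compound 3 `CN(C)c1ccc(C(=O)N2CCC(n3cncc3-c3ccc(OS(=O)(=O)c4cccc(C#N)c4)cc3)CC2)cc1` — 32 nM

Compound 3 stands second highest of the three numbers in this assay. The step of a 4.5-fold lower number from compound 2 to compound 3 (0.65 log units; beyond the scatter) is modest and lies beyond the scatter; the step of a 290-fold higher number from compound 1 to compound 3 (2.46 log units; beyond the scatter) is large and also beyond the scatter, so compound 3 sits far from compound 1 and closer to compound 2.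

Compound 4 `CNC(=O)c1cccc(S(=O)(=O)Oc2ccc(-c3cncn3C3CCN(C(=O)c4ccc(N(C)C)cc4)CC3)cc2)c1` differs from compound 3 in one place: methylcarbamoyl in place of cyano on an aromatic carbon. Neither measured step covers this exact exchange. The step from compound 1 to compound 3 also acts on the aryl ring carried by the sulfonyl sulfur, but it swaps the whole ring system and was large, which shows that this assay answers strongly to changes in that part of the molecule. The step from compound 2 to compound 3 acts at the other end and was modest. A change that keeps the phenyl ring and only exchanges its substituent is therefore expected to move the number less than the large step did, in a direction the data do not settle; a modest step, a 1.1-fold lower number from compound 3 to compound 4 (0.03 log units; within the scatter), is estimated. Compound 4 is expected to give about 30 nM in this assay, within a range from 8 nM to 120 nM.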

Compound 4, half-maximal inhibitory concentration: 25 nM
Compound 4: middle estimate off by 1.2-fold (0.08 log units), on the high side; measured number inside the range.
By their numbers in this assay, from the lowest: compound 1; then compounds 4 and 3 (each within the scatter of the next); then compound 2.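

In this assay, a 1.3-fold lower number from compound 3 to compound 4 (0.11 log units; within the scatter) shows that, at this place on the ring, meta to a large group, methylcarbamoyl and cyano cannot be told apart, even though methylcarbamoyl has more heavy atoms and adds a hydrogen-bond donor. The exchange also does nothing to close the distance to compound 1: a 230-fold higher number from compound 1 to compound 4 (2.36 log units; beyond the scatter) is of much the same size as a 290-fold higher number from compound 1 to compound 3 (2.46 log units; beyond the scatter), so in both pairs the large step accompanies the replacement of isoquinolin-5-yl by a substituted phenyl ring. No evidence is available to explain why the two substituents give such similar results.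

As far as these compounds go, whether a carboxylic acid or a primary amine at this same place would also stay within the scatter remains open, as does whether methylcarbamoyl would behave alike with methylsulfonyl in place of dimethylamino at the other end of the molecule. The compounds also leave open whether any substituent on the phenyl ring could approach compound 1, or whether that requires the isoquinolin-5-yl ring itself.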